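Triazole-linked coumarin ethers: an aryl swap in A549 cells

The source may report more compounds than this note shows. Statements on the series, on what has been measured and on what is new or still open speak of the compounds shown alone.

Measured so far:
Compound 1 `O=c1cc(-n2cc(COc3cccnc3)nn2)c2cc(Br)ccc2o1`: 24800 nM
Compound 2 `O=c1cc(-n2cc(COc3ccccc3O)nn2)c2cc(Br)ccc2o1`: 7940 nM
Compound 3 `CCc1ccc(OCc2cn(-c3cc(=O)oc4ccc(Br)cc34)nn2)cc1`: 11600 nM

On these numbers compound 3 stands second highest of three in a functional assay on A549 cells (Homo sapiens) for antiproliferative activity, read by MTT assay, with a stated time of 48 h; on this read-out higher numbers stand for weaker inhibition and lower numbers for stronger inhibition. Its nearest neighbour is compound 2, with a 1.5-fold higher number from compound 2 to compound 3 (0.16 log units; within the scatter), and its furthest is compound 1, with a 2.1-fold lower number from compound 1 to compound 3 (0.33 log units; beyond the scatter). Compound 4 `COC(=O)c1ccc(OCc2cn(-c3cc(=O)oc4ccc(Br)cc34)nn2)cc1` differs from compound 3 in one place: methoxycarbonyl in place of ethyl on an aromatic carbon. The measured steps all exchange the group on the oxygen on a saturated carbon, the same part of the molecule: a 3.1-fold lower number from compound 1 to compound 2 (0.49 log units; beyond the scatter) and a 2.1-fold lower number from compound 1 to compound 3 (0.33 log units; beyond the scatter) are modest, while a 1.5-fold higher number from compound 2 to compound 3 (0.16 log units; within the scatter). Among the compounds with values here, none of them carries a methoxycarbonyl, so no step points a direction for this change. A step within the scatter is therefore expected, a 1.0-fold higher number from compound 3 to compound 4 (0.01 log units; within the scatter). Compound 4 is estimated at 12000 nM in this assay, with a range from 4500 nM to 32000 nM.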

Compound 4, half-maximal inhibitory concentration: 660 nM
For compound 4 the middle estimate is 18-fold (1.26 log units) above the measured one; the measured number lies below the stated range.
By their numbers in this assay, from the lowest: compound 4; then compounds 2 and 3 (each within the scatter of the next); then compound 1.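

In this assay, methoxycarbonyl in place of ethyl on an aromatic carbon, para to a large group, gives an 18-fold lower number from compound 3 to compound 4 (1.24 log units; beyond the scatter), a large step. The earlier steps shown here exchanged the whole group on the oxygen and stayed modest or within the scatter, whereas this one shows that changing a single substituent on the retained phenyl ring can move the number much further. Nothing at hand says why this change has such an effect.

Whether the methoxycarbonyl itself is required remains open, since the compounds shown do not tell how a carboxylic acid or an amide would read at this place. They also leave open whether the same group would have a comparable effect at another place on the ring.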